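A few compounds are considered here, and "the series" means these few. Any claim that something is new, unique, unknown or untested is made for them only; others in the source may bear on it.

Compound 1 `COc1cc(/C=N/Nc2nc(-c3ccc(Br)cc3)cs2)cc(Br)c1OC` and compound 2 `COc1ccccc1-c1csc(N/N=C/c2cc(OC)c(OC)c(Br)c2Br)n1` are the two members of this series with a result. In a functional assay on HepG2 cells (Homo sapiens) for inhibition, read by MTT assay, with a stated time of 48 h (a lower number here means a stronger inhibitor, a higher number a weaker inhibitor), compound 1 gives 64600 nM. Compound 2 reaches only a limit in this assay, > 100000 nM, so its standing rests on the limit of > 100000 nM in this assay, at which 1 of the 2 values shown sits, and not on a number. Compound 3 `COc1cc(/C=N/Nc2nc(-c3ccc(Br)cc3)cs2)c(Br)c(Br)c1OC` differs from compound 2 in one place: 4-bromophenyl in place of 2-methoxyphenyl on an aromatic carbon. Within the data shown here, no step between measured compounds covers that change on its own. Compound 1, whose structure also carries 4-bromophenyl, sits at 64600 nM in this assay, so compound 3 is expected to land near that value. The expected step of an at least 1.4-fold lower number from compound 2 to compound 3 (0.15 log units; that floor lies within the scatter) therefore points toward a stronger inhibitor, though its size cannot be fixed from a limit. Compound 3 is expected at 70000 nM in this assay, within 30000 nM to 200000 nM.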

Compound 3, half-maximal inhibitory concentration: > 100000 nM
Compound 3: only a limit was reported (the forecaster's own chance of this, stated with the estimate: 40%); middle value at least 1.4-fold (0.15 log units) from the limit.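

Placing 4-bromophenyl instead of 2-methoxyphenyl on the aromatic carbon next to the ring nitrogen yields no readable change: compound 3, like compound 2, is reported only as a limit, so the step between them cannot be read. On these data alone, with 4-bromophenyl held in place, bromo in place of hydrogen on an aromatic carbon gives, in this assay, an at least 1.5-fold higher number from compound 1 to compound 3 (0.18 log units; that floor lies within the scatter), and this gives no sign of a stronger inhibitor, although the size of the step stays open. Only compound 1 now has a number, and the other readings stop at one limit: the limit of > 100000 nM in this assay, at which 2 of the 3 values shown sit.

As far as these compounds go, how 4-bromophenyl and 2-methoxyphenyl rank at this position stays open, as does how far compound 2 and compound 3 lie from the limit. From the compounds shown here alone, it is also open whether an amine or a carboxylic acid at this position would give a number that can be read.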